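Furan-2-yl in Place of Ethynyl on the Nucleoside Core

The source may report more compounds than this note shows. Statements on the series, on what has been measured and on what is new or still open speak of the compounds shown alone.

In a functional assay on K562 cells (Homo sapiens), read by MTT assay, with a stated time of 72 h (a lower number here means a stronger inhibitor, a higher number a weaker inhibitor), compound 2 `C#Cc1cn([C@@H]2O[C@H](CO)[C@@H](O)[C@H]2O)c2ncnc(OC)c12` gives 300 nM, the lowest of the two numbers measured. Compound 1 `COc1nc(N)nc2c1c(-c1cc3ccccc3o1)cn2[C@@H]1O[C@H](CO)[C@@H](O)[C@H]1O` gives 14600 nM in this assay, a gap from compound 2 that lies beyond the usual scatter. Compound 3 `CN(C)c1ncnc2c1c(-c1cc3ccccc3o1)cn2[C@@H]1O[C@H](CO)[C@@H](O)[C@H]1O` gives > 20000 nM, which is a limit of the assay rather than a number; this is the limit of > 20000 nM in this assay, at which 1 of the 3 values shown sits.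

Compound 4 `COc1ncnc2c1c(-c1ccco1)cn2[C@@H]1O[C@H](CO)[C@@H](O)[C@H]1O` is not yet measured; it differs from compound 2 by furan-2-yl in place of ethynyl on an aromatic carbon. Compound 1 and compound 3, which carry aromatic groups on that carbon but also differ elsewhere, both give weak results, while the ethynyl of compound 2 gives the lowest number. A weakening step is therefore expected, a 10-fold higher number from compound 2 to compound 4 (1.00 log units; beyond the scatter), beyond the scatter. Compound 4 is estimated at 3000 nM, between 800 nM and 15000 nM.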

Compound 4, half-maximal inhibitory concentration: 60 nM
The estimate for compound 4 lay 50-fold (1.70 log units) above the measured number; measured number below the stated range.
By their numbers in this assay, from the lowest: compound 4; then compound 2; then compound 1. At a limit, above all of these: compound 3.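

In this assay, furan-2-yl in place of ethynyl gives a 5.0-fold lower number from compound 2 to compound 4 (0.70 log units; beyond the scatter). This is the first step shown between compounds that differ in one place, and it shows that ethynyl is not needed for a low number at this aromatic carbon, since a five-membered aromatic ring with 1 hetero atom serves better there. Nothing shown gives a cause for this step.

The compounds shown leave open how a thiophene ring or an aminomethyl group would fare on this carbon, and whether the step would hold with an amine in place of the methoxy group.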